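Compound 4 in the mGlu5 series: from nitro to dichloro

The compounds below may be only part of what the source reports. "The series", "measured", "known", "first", "only" and "open" are said of these compounds alone.

Measured so far in a functional assay on cells for positive allosteric modulation of metabotropic glutamate receptor 5 (Rattus norvegicus), read by calcium flux; on this read-out higher numbers stand for an effect only at larger amounts of compound and lower numbers for an effect already at smaller amounts:
Compound 1 `COc1cccc(C(=O)Nc2cc(-c3ccccc3)nn2-c2ccccc2)c1` gives 102 nM.
Compound 2 `Cc1ccc(C(=O)Nc2cc(-c3ccccc3)nn2-c2ccccc2)cc1` gives 64 nM.
Compound 3 `O=C(Nc1cc(-c2ccccc2)nn1-c1ccccc1)c1ccc([N+](=O)[O-])cc1` gives 10.7 nM.

Compound 3 holds the lowest number of the three. Its step from compound 1 is a 9.5-fold lower number from compound 1 to compound 3 (0.98 log units; beyond the scatter), and from compound 2 it is a 6.0-fold lower number from compound 2 to compound 3 (0.78 log units; beyond the scatter); both steps lie beyond the scatter, so compound 3 stands apart from the other two, which differ from each other only by a 1.6-fold lower number from compound 1 to compound 2 (0.20 log units; within the scatter).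

Compound 4 `O=C(Nc1cc(-c2ccccc2)nn1-c1ccccc1)c1ccc(Cl)c(Cl)c1` is not yet measured. Compared with compound 3 the change is 3,4-dichlorophenyl in place of 4-nitrophenyl on a carbonyl carbon. Within the data shown here, no measured step swaps the 4-nitrophenyl for a 3,4-dichlorophenyl, so there is no direct guide. What the measured steps show is that the 4-nitrophenyl gave the lowest number, while the 3-methoxyphenyl of compound 1 and the 4-methylphenyl of compound 2 gave higher ones. A different substituted phenyl is therefore expected to land somewhere between those extremes. The expected step is a 2.8-fold higher number from compound 3 to compound 4 (0.45 log units; beyond the scatter). For compound 4 the estimate in this assay is 30 nM, with a range from 8 nM to 120 nM.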

Compound 4, half-maximal effective concentration: 13 nM
Beside the measured number, compound 4's estimate is 2.3-fold (0.36 log units) above it, within the range that was stated.
By their numbers in this assay, from the lowest: compounds 3 and 4 (each within the scatter of the next); then compounds 2 and 1 (each within the scatter of the next).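

In this assay, swapping the 4-nitrophenyl for the 3,4-dichlorophenyl on the carbonyl carbon leaves the number within the scatter (a 1.2-fold higher number from compound 3 to compound 4 (0.08 log units; within the scatter)), so among these compounds a low number at this place does not require a nitro group or its hydrogen-bond acceptors. Among these compounds, compound 4 also stands clearly apart from the two compounds with higher numbers (a 4.9-fold lower number from compound 2 to compound 4 (0.69 log units; beyond the scatter); a 7.8-fold lower number from compound 1 to compound 4 (0.89 log units; beyond the scatter)), which makes compound 3 no longer the only compound with a low number. Nothing available here explains why two such different groups give matching results.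

The compounds shown leave open whether both chlorines are needed, as a phenyl carrying one chlorine would show. Going by these compounds, they also leave open how this place responds to a phenyl carrying an amine or a carboxylic acid, and all four compounds share the same core, so other places remain untested.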